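Working notes on a shared core: toward compound 4

The compounds below may be only part of what the source reports. "The series", "measured", "known", "first", "only" and "open" are said of these compounds alone.

Compound 3 `CNc1ncncc1-c1nc2cc(F)c(F)cc2n1C1CC1` stands lowest of the two numbers in an ADME assay on cells for inhibition of cytochrome P450 11B1, mitochondrial (Homo sapiens), read by HPLC, with a stated time of 60 min (on this read-out lower numbers stand for stronger inhibition and higher numbers for weaker inhibition), where compound 3 gives 390 nM. Its nearest neighbour, compound 1 `Fc1ccc2nc(-c3cn[nH]c3)n(C3CC3)c2c1`, gives 1670 nM in this assay. Compound 2 `Fc1ccc2nc(-c3cccnn3)n(C3CC3)c2c1` reaches only the limit of > 10000 nM in this assay. Going by the values given here, the single measured step, an at least 5.9-fold higher number from compound 1 to compound 2 (0.77 log units; beyond the scatter), concerns a different ring from the one changed here and so bears only loosely on compound 4 `CC(F)(F)c1ncncc1-c1nc2cc(F)c(F)cc2n1C1CC1`, which differs from compound 3 by 1,1-difluoroethyl in place of methylamino on an aromatic carbon. Among the compounds with values here, no measured step tests this exchange; the expectation is therefore cautious, a weakening of a 2.3-fold higher number from compound 3 to compound 4 (0.36 log units; beyond the scatter) in this assay, within the spread already seen across the series. Compound 4 is estimated at 900 nM, between 200 nM and 4000 nM.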

Compound 4, half-maximal inhibitory concentration: 5720 nM
Compound 4: the middle estimate sits 6.4-fold (0.80 log units) below what was measured; the measured number lies above the stated range.
By their numbers in this assay, from the lowest: compound 3; then compound 1; then compound 4. At a limit, above all of these: compound 2.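

In this assay, this position on the six-membered aromatic ring with 2 nitrogen proves sensitive to the group it carries: 1,1-difluoroethyl in place of methylamino gives a 15-fold higher number from compound 3 to compound 4 (1.17 log units; beyond the scatter), a large step. Going by these compounds alone, this is the first measured exchange at this position, and it leaves the shared core otherwise unchanged. Nothing shown gives a cause for the size of this step.

The compounds shown leave open whether the hydrogen-bond donor of methylamino or the size of the entering group accounts for the step. A dimethylamino group or an ethyl chain at this position would separate the two.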